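The compounds below may be only part of what the source reports. "The series", "measured", "known", "first", "only" and "open" are said of these compounds alone.

Compound 3 `COc1cc(NC(C)CCCNC(=O)NNC(=O)Nc2ccc(O)cc2)c2ncccc2c1` gives 142000 nM in a functional assay on MIA PaCa-2 cells (Homo sapiens) for inhibition, read by MTT assay, with a stated time of 72 h (a higher number here means a weaker inhibitor, a lower number a stronger inhibitor), the highest of the three numbers shown, beyond the scatter from both others. Compound 2 `COc1cc(NC(C)CCCNC(=O)Nc2ccc(F)cc2)c2ncccc2c1` gives 21000 nM in this assay. Within the data shown here, the one measured step that bears on the present change is a 6.8-fold higher number from compound 2 to compound 3 (0.83 log units; beyond the scatter), the only step in which a hydroxy group came in. Compound 4 `COc1cc(NC(C)CCCNC(=O)NNC(=O)Nc2ccc(Cl)cc2)c2ncccc2c1` differs from compound 3 by chloro in place of hydroxy on an aromatic carbon. A marked drop is expected, because compound 1 `COc1cc(NC(C)CCCNC(=O)NNC(=O)Nc2cc(C(F)(F)F)cc(C(F)(F)F)c2)c2ncccc2c1`, which carries two trifluoromethyl groups instead of the hydroxy, gives 20000 nM in this assay, close to compound 2. The step from compound 3 to compound 4 is therefore expected to be a 5.7-fold lower number from compound 3 to compound 4 (0.75 log units; beyond the scatter). Compound 4 is estimated to give 25000 nM, within 10000 nM to 60000 nM.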

Compound 4, half-maximal inhibitory concentration: >= 250000 nM
Compound 4: only a limit was reported; the forecaster's own chance of this, stated with the estimate: 5%; middle value at least 10-fold (1.00 log units) from the limit.
By their numbers in this assay, from the lowest: compounds 1 and 2 (each within the scatter of the next); then compound 3. At a limit, above all of these: compound 4.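

Compound 4 reached only a limit of the assay: the limit of >= 250000 nM in this assay, at which 1 of the 4 values shown sits. Chloro in place of hydroxy on this aromatic carbon therefore brought no gain (an at least 1.7-fold higher number from compound 3 to compound 4 (0.24 log units; that floor lies within the scatter)), although a lower number had seemed likely. With ((4-chlorophenyl)carbamoyl)amino in place of 4-fluorophenyl, the number also rises (an at least 11-fold higher number from compound 2 to compound 4 (1.07 log units; beyond the scatter)), in the same direction as the hydroxy compound, while compound 1 goes against this pattern, lying within the scatter of compound 2.

As far as these compounds go, how far beyond the limit compound 4 lies stays unknown, so the true size of both steps is open. Also open, from the compounds shown here alone, is whether an amine or a carboxylic acid on this aromatic carbon would lower the number.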